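Removing the hydroxy from a silyl-protected cyclopentenone

The compounds below may be only part of what the source reports. "The series", "measured", "known", "first", "only" and "open" are said of these compounds alone.

Measured compounds:
- Compound 1, `COc1ccc(C2=C(c3cc(OC)c(OC)c(OC)c3)C(=O)CC2O)cc1`: "not determined" (no result reported)
- Compound 2, `COc1cc(C2=C(c3ccccc3)C(O[SiH2]C(C)(C)C)CC2=O)cc(OC)c1OC`: > 100 ug/mL
- Compound 3, `COc1ccc(C2=C(c3cc(OC)c(OC)c(OC)c3)C(=O)CC2O[SiH2]C(C)(C)C)cc1O`: 6.5 ug/mL

Going by the values given here, in an ADME assay on KB cells (Homo sapiens) for cytotoxicity, read by MTT assay, with a stated time of 72 h (on this read-out higher numbers stand for weaker inhibition and lower numbers for stronger inhibition), compound 3 gives 6.5 ug/mL, the only single number among the three entries. Compound 2 gives > 100 ug/mL, which is a limit of the assay and not a number. For compound 1 no result is reported.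

The next compound, compound 4, `COc1ccc(C2=C(c3cc(OC)c(OC)c(OC)c3)C(=O)CC2O[SiH2]C(C)(C)C)cc1`, differs from compound 3 by hydrogen in place of hydroxy on an aromatic carbon. Among the compounds with values here, the one measured step that touches this part of the molecule is an at least 15-fold lower number from compound 2 to compound 3 (1.18 log units; beyond the scatter), which exchanged phenyl for 3-hydroxy-4-methoxyphenyl and moved the value from the limit of > 100 ug/mL in this assay, at which 1 of the 3 values shown sits, down to a number. Compound 4 keeps the methoxy of that group and gives up only the hydroxy, so part of that gain may be kept. A step upward beyond the scatter is expected, though smaller than the measured one. Compound 4 is therefore estimated at 18 ug/mL, within a range of 5 ug/mL to 65 ug/mL, meaning an expected step of a 2.8-fold higher number from compound 3 to compound 4 (0.44 log units; beyond the scatter).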

Compound 4, half-maximal inhibitory concentration: > 100 ug/mL
Compound 4 ended at the assay's limit; the forecaster's own chance of this, stated with the estimate: 15%; at least 5.5-fold (0.74 log units) between middle value and limit.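

In this assay, taking away only the hydroxy gives an at least 15-fold higher number from compound 3 to compound 4 (1.18 log units; beyond the scatter), so within this pair the measurable cytotoxicity depends on that one group on the aromatic ring. The earlier change from phenyl to 3-hydroxy-4-methoxyphenyl introduced two groups at once, whereas this pair separates them and shows that 4-methoxyphenyl, with the methoxy kept, does not preserve a measurable value. Compound 4 stands at a limit of the assay and not at a number: the limit of > 100 ug/mL in this assay, at which 2 of the 4 values shown sit.

The step between compound 2 and compound 4 cannot be read, as two limits give no size. The compounds shown leave open whether another group on this aromatic carbon, such as an amine or a carboxylic acid, could take the place of the hydroxy.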